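This account rests on a few compounds, and the source may have more. Where it says the series, first, only, none or still open, it means among the compounds named here.

Of the compounds shown here, three sharing the same five-membered aromatic core have been measured in an assay on CHO-K1 cells for displacement of a labelled ligand from prostaglandin E2 receptor EP1 subtype (Homo sapiens); a higher number here means a weaker inhibitor, a lower number a stronger inhibitor. Compound 1 `Cc1cc(C(=O)O)nn1C(C)c1cc(Cl)ccc1OCc1ccccc1` gives 10 nM. Compound 2 `Cc1cc(C(=O)Nc2ccc(F)cc2)nn1Cc1cc(Cl)ccc1OCc1ccccc1` gives 79.4 nM, and compound 3 `Cc1cc(C(=O)NN2CCOCC2)nn1Cc1cc(Cl)ccc1OCC(C)C` gives 251 nM. Among these three numbers, compound 2 stands second highest: its nearest neighbour is compound 3, whose number is higher by a gap beyond the scatter, and its furthest is compound 1, whose number is lower by a gap beyond the scatter.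

The next compound to be measured is compound 4 `Cc1cc(NC(=O)C(C)C)nn1Cc1cc(Cl)ccc1OCc1ccccc1`. It differs from compound 2 in one place: (isopropylcarbonyl)amino in place of (4-fluorophenyl)carbamoyl on an aromatic carbon. The group that leaves carries an aromatic ring; the group that enters has no ring, and the order of carbonyl and amide nitrogen relative to the core is turned around. Within the data shown here, no pair of measured compounds differs in just this way, so the size of the step has to be judged from the three values alone. Compound 1, with a carboxylic acid in this place, gives 10 nM, while compound 2 with an amide there gives 79.4 nM; a further move away from that acid is expected to push the number upward rather than down. The step from compound 2 to compound 4 in this assay is expected to be a 3.8-fold higher number from compound 2 to compound 4 (0.58 log units; beyond the scatter), a shift toward a weaker inhibitor beyond the scatter. Compound 4 is therefore estimated at 300 nM in this assay, within a range from 60 nM to 1500 nM.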

Compound 4, half-maximal inhibitory concentration: 25.1 nM
Estimate against measurement, compound 4: 12-fold (1.08 log units) above, and the stated range ends above it.
By their numbers in this assay, from the lowest: compound 1; then compound 4; then compound 2; then compound 3.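

In this assay the swap of (4-fluorophenyl)carbamoyl for (isopropylcarbonyl)amino gives a 3.2-fold lower number from compound 2 to compound 4 (0.50 log units; beyond the scatter) and so moves toward a stronger inhibitor, which shows that this aromatic carbon next to the ring nitrogen accepts a quite different group without loss. The aromatic ring of the leaving group is therefore not needed to reach this level of binding in this series, and a smaller group with no ring does at least as well. Both groups count the same hydrogen-bond donor and acceptor, but nothing shown gives a reason for the size or direction of this step.

The step joins two changes in one, the loss of the ring and the turned-around order of carbonyl and amide nitrogen, and the compounds shown cannot separate them. Also open, as far as these compounds go, is how the number would move with a plain amine on this carbon, or with a longer chain or a phenyl group in place of the isopropyl on the turned-around amide.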